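This account rests on a few compounds, and the source may have more. Where it says the series, first, only, none or still open, it means among the compounds named here.

Working notes, series of chloro-substituted cores. Compound 1 `Clc1ccc2ncnc(NCc3ccccc3)c2c1` in a functional assay on HEK293 cells for antagonist activity at metabotropic glutamate receptor 5 (Rattus norvegicus), read by calcium flux (on this read-out lower numbers stand for stronger inhibition and higher numbers for weaker inhibition), gives only the assay limit, > 30000 nM. Compound 2 `Clc1ccc(CNc2ncnc3ccc(Cl)cc23)cc1` in this assay likewise reports only a limit, > 30000 nM. The step that the two limits leave unreadable from compound 1 to compound 2 therefore cannot be sized; its two values sit at the limit of > 30000 nM in this assay, at which 2 of the 2 values shown sit. Compound 3 `Clc1cccc(CNc2ncnc3ccc(Cl)cc23)c1` differs from compound 1 by chloro in place of hydrogen on an aromatic carbon. Among the compounds with values here, the one measured step is unreadable, so no measured step bears on this change and no direction can be called beyond the scatter. Compound 3 is expected to land at 40000 nM, range 15000 nM to 150000 nM, most probably as a limit again. The expected step is a step that the limit leaves unreadable from compound 1 to compound 3.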

Compound 3, half-maximal inhibitory concentration: > 30000 nM
Compound 3 gave a limit, no number; the forecaster's own chance of this, stated with the estimate: 85%; the middle value does not contradict the limit.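

Compound 1 and compound 3 both give only a limit, so no step between them can be read: the limit of > 30000 nM in this assay, at which 3 of the 3 values shown sit.

The compounds shown leave open whether chloro in place of hydrogen on an aromatic carbon changes inhibition in this assay at all.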